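The source may hold more compounds than are shown below. What is called first, only, known or untested is meant among the compounds shown, and "the series" means these compounds.

Working notes on the series, read in a functional assay on SK-MEL-28 cells (Homo sapiens) for inhibition, read by colorimetric assay and MTT assay, with a stated time of 72 h; a higher number here means a weaker inhibitor, a lower number a stronger inhibitor. Compound 1 `Cn1c2cnc1OCCCCCCCCCCOc1cc3ccccc3cc1-2` gives 33000 nM, and compound 2 `CCCCOc1ncc(-c2ccccc2OC)n1C` gives 82000 nM. Compound 2 therefore holds the higher of the two numbers, making it the weaker inhibitor of the pair, and the gap lies beyond the scatter. Among the measured compounds shown here, no step between measured compounds that differ in one place is available. Compound 3 `C=CCCCCOc1ncc(-c2ccccc2OC)n1C` differs from compound 2 in one place vinyl in place of hydrogen on a saturated chain carbon, four bonds along the chain from an oxygen on an aromatic ring. In this assay, a small move toward a lower number is expected, not clearly beyond the scatter. The estimated change is a 1.6-fold lower number from compound 2 to compound 3 (0.21 log units; within the scatter). The expected value for compound 3 is 50000 nM, with an estimated range from 20000 nM to 110000 nM.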

Compound 3, half-maximal inhibitory concentration: 13000 nM
Compound 3: middle estimate off by 3.8-fold (0.59 log units), on the high side; measured number outside the range, below it.
By their numbers in this assay, from the lowest: compound 3; then compound 1; then compound 2.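

In this assay, vinyl in place of hydrogen on a saturated chain carbon, four bonds along the chain from an oxygen on an aromatic ring, gives a 6.3-fold lower number from compound 2 to compound 3 (0.80 log units; beyond the scatter), so the read-out responds to a change at this position by more than the scatter. Among the compounds shown here, this is the only one-place step so far, and it adds 2 heavy atoms and 1 double bond outside aromatic rings together, so it cannot separate the added chain length from the double bond. No measurement on hand accounts for this step.

Open, going by these compounds, is whether a saturated hexyl chain would read like compound 3 or like compound 2. Also open, on these data alone, is how an amine or a carboxylic acid at the end of the chain would read in this assay.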